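Amide-to-urea switch on the compound 1 scaffold

The source may report more compounds than this note shows. Statements on the series, on what has been measured and on what is new or still open speak of the compounds shown alone.

Measured so far:
compound 1, `COc1cc(-c2nn(-c3cccc(NC(=O)c4ccc(Cl)c(C(F)(F)F)c4)c3)cc2-c2ccncc2)ccc1Cl`: 5390 nM
compound 2, `O=C(Nc1cccc(-n2cc(-c3ccncc3)c(-c3ccc(Cl)c(O)c3)n2)c1)Nc1cc(C(F)(F)F)cc(C(F)(F)F)c1`: 1020 nM
compound 3, `O=C(Nc1cccc(-n2cc(-c3ccncc3)c(-c3ccc(Cl)c(O)c3)n2)c1)Nc1ccc(Cl)c(C(F)(F)F)c1`: 951 nM

In a functional assay on NCI-H23 cells (Homo sapiens) for inhibition, read by sulforhodamine B assay, with a stated time of 48 h (on this read-out lower numbers stand for stronger inhibition of growth and higher numbers for weaker inhibition of growth), compound 1 gives 5390 nM, the highest of the three numbers, and its gap to both compound 2 and compound 3 lies beyond the scatter. Compound 2 and compound 3 sit close together, and what they show is that exchanging one halogenated phenyl for another on the urea end leaves this assay unchanged within scatter.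

Compound 4, `COc1cc(-c2nn(-c3cccc(NC(=O)Nc4ccc(Cl)c(Cl)c4)c3)cc2-c2ccncc2)ccc1Cl`, is not yet measured. It keeps the methoxy-bearing core of compound 1 and carries (3,4-dichlorophenyl)amino in place of 4-chloro-3-(trifluoromethyl)phenyl on a carbonyl carbon. This turns the amide of compound 1 into a urea, the linkage that compound 2 and compound 3 also carry, though neither shares the methoxy group of compound 1, so no single-change comparison exists for this step.

The expectation for compound 4 is a move toward lower numbers in this assay, a 2.2-fold lower number from compound 1 to compound 4 (0.33 log units; beyond the scatter), smaller than the gap from compound 1 to compound 2 or compound 3, since part of that gap may belong to the hydroxy-for-methoxy difference. Compound 4 is estimated at 2500 nM, with a range of 900 nM to 7000 nM.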

Compound 4, concentration for 50% growth inhibition: 1410 nM
Compound 4: the middle estimate sits 1.8-fold (0.25 log units) above what was measured, within the range that was stated.
By their numbers in this assay, from the lowest: compounds 3, 2 and 4 (each within the scatter of the next); then compound 1.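

In this assay, among the compounds shown here, with the methoxy-bearing core of compound 1 held fixed, (3,4-dichlorophenyl)amino in place of 4-chloro-3-(trifluoromethyl)phenyl on a carbonyl carbon gives a 3.8-fold lower number from compound 1 to compound 4 (0.58 log units; beyond the scatter), the first comparison that differs in one place. This step turns the amide into a urea and shows that a lower number at this position can be reached with the methoxy group still present, so it does not depend on the hydroxy group carried by compound 2 and compound 3. No measurement on these compounds accounts for the size of the step.

Still open, on these data alone, is how much of the step belongs to the amino nitrogen that enters and how much to the change of substituents on the aromatic ring, since the two change together in this single comparison. Also open, as far as these compounds go, is how a methylamino group on the same carbonyl carbon, with its nitrogen carrying a methyl group instead of the amide hydrogen, would read in this assay.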